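The source may hold more compounds than are shown below. What is called first, only, known or untested is meant among the compounds shown, and "the series" means these compounds.

In a functional assay on the whole organism (Abdomen, strain Swiss) with Mus musculus as the target, with a stated time of 30 min (on this read-out higher numbers stand for an effect only at larger amounts of compound and lower numbers for an effect already at smaller amounts), compound 1, `O=C(Nc1ccc(Cl)cc1)Nc1ccc(C(=O)/C=C/c2ccccc2)cc1`, gives 7.25 umol/kg. Compound 3, `O=C(/C=C/c1ccc(Cl)cc1)c1ccc(NC(=S)Nc2ccc(Cl)cc2)cc1`, gives 7.59 umol/kg in this assay, and compound 2, `O=C(/C=C/c1ccc(Cl)c(Cl)c1)c1ccc(NC(=S)Nc2ccc(Cl)cc2)cc1`, gives 6.15 umol/kg; all three numbers lie within the scatter of one another, so none stands apart. Compound 2 differs from compound 3 by chloro in place of hydrogen on an aromatic carbon, and that change made a 1.2-fold lower number from compound 3 to compound 2 (0.09 log units; within the scatter). Compound 4, `O=C(Nc1ccc(Cl)cc1)Nc1ccc(C(=O)/C=C/c2ccc(Cl)cc2)cc1`, has not been measured in this assay. Among the measured compounds shown here, it differs from compound 1 by chloro in place of hydrogen on an aromatic carbon, the same kind of change as the one from compound 3 to compound 2, though the place is not the same: in compound 2 the entering chloro is ortho to a chloro group and meta to a large group, whereas in compound 4 it is para to a large group. The difference between the core of compound 1 and the core of compound 3 is not broken down here. Because a 1.2-fold lower number from compound 3 to compound 2 (0.09 log units; within the scatter) lies within the scatter, the step from compound 1 to compound 4 is expected to be small as well, a 1.0-fold lower number from compound 1 to compound 4 (0.02 log units; within the scatter). Compound 4 is therefore estimated at 7 umol/kg in this assay, most likely between 4 umol/kg and 12 umol/kg.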

Compound 4, dose for 50% inhibition: 45.4 umol/kg
Compound 4: middle estimate off by 6.5-fold (0.81 log units), on the low side; measured number outside the range, above it.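

On the shared core of compound 1, chloro in place of hydrogen, para to a large group, gave a 6.3-fold higher number from compound 1 to compound 4 (0.80 log units; beyond the scatter) in this assay, so compound 4 needs a larger amount of compound for the same effect. Set beside the earlier step, this shows that the change cannot be carried unaltered from one core to the other in this series: the same change on two cores in this assay, a 1.2-fold lower number (0.09 log units; within the scatter) from compound 3 to compound 2 and a 6.3-fold higher number (0.80 log units; beyond the scatter) from compound 1 to compound 4, 7.7-fold (0.89 log units) apart, beyond the scatter of two such steps. Among the compounds shown here, it does not show what sets the gap, since each core offers only one such pair and the entering chloro does not sit at the same place in the two steps, so the core and the place cannot be told apart.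

Going by these compounds, whether the same place would respond in this way to a group other than chloro, such as fluoro, methyl or methoxy, remains open. Also open, on these data alone, is whether chloro at that place would give a similar step on a further core, such as one carrying an amine on the phenyl ring.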